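Swapping nitro for trifluoromethyl on the sulfonyl aryl ring

The compounds below may be only part of what the source reports. "The series", "measured", "known", "first", "only" and "open" are said of these compounds alone.

The compounds share one core, an amine-bearing benzofuran ketone joined to a piperazine whose far nitrogen carries a changing group. Compound 1 `CCN(CC)c1ccc2cc(C(=O)c3ccc(N4CCN(C(=O)COc5ccc(Cl)cc5Cl)CC4)cc3)oc2c1` carries a ((2,4-dichlorophenoxy)methyl)carbonyl there, and in a functional assay on MCF7 cells (Homo sapiens) for cytotoxicity, read by MTT assay, with a stated time of 48 h (on this read-out higher numbers stand for weaker inhibition and lower numbers for stronger inhibition), compound 1 gives 12400 nM. Compound 2 `CCN(CC)c1ccc2cc(C(=O)c3ccc(N4CCN(S(=O)(=O)c5ccc(Br)cc5)CC4)cc3)oc2c1` carries a (4-bromophenyl)sulfonyl instead, and in this assay compound 2 gives 26100 nM, a change of a 2.1-fold higher number from compound 1 to compound 2 (0.32 log units; beyond the scatter). Compound 3 `CCN(CC)c1ccc2cc(C(=O)c3ccc(N4CCN(S(=O)(=O)c5ccc([N+](=O)[O-])cc5)CC4)cc3)oc2c1` carries a (4-nitrophenyl)sulfonyl. For compound 3 the assay reports only a limit, > 40000 nM, so compound 3 stands at the weak end of what has been measured, and the limit of > 40000 nM in this assay, at which 1 of the 3 values shown sits, is where its value sits. The step of an at least 1.5-fold higher number from compound 2 to compound 3 (0.18 log units; that floor lies within the scatter) and the step of an at least 3.2-fold higher number from compound 1 to compound 3 (0.50 log units; beyond the scatter) place compound 3 no stronger than the others.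

Compound 4 `CCN(CC)c1ccc2cc(C(=O)c3ccc(N4CCN(S(=O)(=O)c5ccc(C(F)(F)F)cc5)CC4)cc3)oc2c1` differs from compound 3 by trifluoromethyl in place of nitro on an aromatic carbon. Within the data shown here, the step from bromo to nitro, an at least 1.5-fold higher number from compound 2 to compound 3 (0.18 log units; that floor lies within the scatter), is the only measured change at this ring position, and it was small. A similar small step, or none beyond the scatter, is therefore expected for compound 4, with a real chance that only a limit is reported again. Compound 4 is estimated to give 35000 nM, in a range from 15000 nM to 80000 nM, which would mean a step of an at least 1.1-fold lower number from compound 3 to compound 4 (0.05 log units; that floor lies within the scatter).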

Compound 4, half-maximal inhibitory concentration: > 40000 nM
Compound 4 was reported as a limit; the forecaster's own chance of this, stated with the estimate: 40%; at least 1.1-fold (0.05 log units) between middle value and limit.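

Compound 3 and compound 4 are both reported only as limits in this assay, so the step between them cannot be read, and neither group can be ranked against the other: the limit of > 40000 nM in this assay, at which 2 of the 4 values shown sit.

What this adds is a second comparison with the bromo compound: trifluoromethyl in place of bromo gives an at least 1.5-fold higher number from compound 2 to compound 4 (0.18 log units; that floor lies within the scatter). That is only a floor, and the true gap between compound 2 and compound 4 could be larger, but what is printed does not yet separate them beyond the usual scatter. Among the three sulfonyl compounds shown, compound 2 alone gives a value that is not a limit, while the nitro and trifluoromethyl groups at this ring carbon, para to a large group, both leave the result at a limit.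

The compounds shown leave open what an amine or a carboxylic acid on this same ring carbon would give, and whether either would bring a reading that is not a limit. They also leave open how the ring would read with a plain methyl group here, or with no group on this carbon at all.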